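The compounds below may be only part of what the source reports. "The series", "measured", "known", "first", "only" and "open" are said of these compounds alone.

Measured so far in a functional assay on HeLa cells (Homo sapiens) for antiproliferative activity; on this read-out lower numbers stand for stronger inhibition and higher numbers for weaker inhibition
Compound 1 `CCCCCCCn1c(CCCC)nc(Cl)c1-c1nc2ccccc2[nH]1` gives 25300 nM
Compound 2 `CCCCc1nc(Cl)c(-c2nc3ccccc3[nH]2)n1Cc1cccc(C)c1` gives 30200 nM

Within the data shown here, with only these two numbers, compound 2 cannot be told apart from the one other compound tested. Among the measured compounds shown here, the single measured step is a 1.2-fold higher number from compound 1 to compound 2 (0.08 log units; within the scatter) and it comes from replacing hexyl with 3-methylphenyl.

Compound 3 `CCCCc1nc(Cl)c(-c2nc3ccccc3[nH]2)n1Cc1ccc(F)cc1` keeps the shared core and alters the same place, on a saturated chain carbon bound to an aromatic nitrogen. The difference is 4-fluorophenyl in place of 3-methylphenyl on a saturated chain carbon bound to an aromatic nitrogen and amounts to 4-fluorophenyl in place of 3-methylphenyl, or 3-methylbenzyl to 4-fluorobenzyl.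

For the measured compounds named here, the step to compound 2 is the only guide. It swapped a chain for an aromatic ring at this place, and that step stayed within the scatter. Going by the values given here, the new change swaps one aromatic ring for another of the same kind, though no measured compound yet carries fluorine. The expected result in this assay is therefore no shift in either direction beyond the scatter, and the estimated change is a 1.1-fold lower number from compound 2 to compound 3 (0.05 log units; within the scatter) at most a small one.

For compound 3 the expected value is 27000 nM with an estimated range from 12000 nM to 60000 nM in this read-out.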

Compound 3, half-maximal inhibitory concentration: 30200 nM
For compound 3 the middle estimate is 1.1-fold (0.05 log units) below the measured one; measured number inside the range.
By their numbers in this assay, from the lowest: compounds 1, 2 and 3 (each within the scatter of the next).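

In this assay, changing the aromatic ring itself, with 4-fluorophenyl in place of 3-methylphenyl, gives no change at the digits printed from compound 2 to compound 3 (within the scatter), so this second ring behaves no differently from the first at this place, on a saturated chain carbon bound to an aromatic nitrogen. Replacing hexyl with 4-fluorophenyl gives a 1.2-fold higher number from compound 1 to compound 3 (0.08 log units; within the scatter), which means that a straight chain and two differently substituted aromatic rings now all fall within the scatter of one another, and the first compound carrying fluorine does not stand apart from the others. Nothing available explains why the read-out stays so flat across these three groups.

On these data alone, whether an amine, a carboxylic acid or a short chain such as methyl at this place would shift the number remains open, since the three compounds cover only a hexyl chain and two substituted benzyl groups there. The butyl chain and the chlorine stay the same in all three compounds, so these comparisons say nothing about how changes at those places would affect the antiproliferative read-out.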